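A Thiophene Swap on a Weakly Cytotoxic Core

The source may report more compounds than this note shows. Statements on the series, on what has been measured and on what is new or still open speak of the compounds shown alone.

Of the compounds shown here, three sharing one core have been measured. In a functional assay on Ehrlich cells (Mus musculus) for cytotoxicity, read by trypan blue exclusion, with a stated time of 2 h, tested at 10 ug/mL (a higher number here means a stronger effect of the compound at the concentration tested, a lower number a weaker effect), compound 1 `N#CC1=C(N)N(c2ccc(S(N)(=O)=O)cc2)C2=C(CCCC2)C1c1ccccc1O` gives 10%. Compound 2 `N#CC1=C(N)N(c2ccc(S(N)(=O)=O)cc2)C2=C(CCCC2)C1c1ccccc1Cl` gives 0%, and compound 3 `N#CC1=C(N)N(c2ccc(S(N)(=O)=O)cc2)C2=C(CCCC2)C1c1ccc(Cl)cc1Cl` gives 0%. Compound 3 thus stands level with compound 2, and the step of a number 10 percentage points lower from compound 1 to compound 3 (within the scatter) is within the scatter, as are a number 10 percentage points lower from compound 1 to compound 2 (within the scatter) and no change at the digits printed from compound 2 to compound 3 (within the scatter). Compound 4 `N#CC1=C(N)N(c2ccc(S(N)(=O)=O)cc2)C2=C(CCCC2)C1c1cccs1` differs from compound 3 in one place: thiophen-2-yl in place of 2,4-dichlorophenyl on a saturated ring carbon. Within the data shown here, the measured step that bears on this is a number 10 percentage points lower from compound 1 to compound 3 (within the scatter), the only earlier swap of the whole ring on that carbon, and it stayed within the scatter. Nothing among these numbers points to a move beyond the scatter in this assay. The step is therefore expected to be a number 3 percentage points higher from compound 3 to compound 4 (within the scatter). Compound 4 is expected to give 3%, within 0% to 15%.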

Compound 4, a percentage reported as activity, at one concentration (the size of the read-out at that concentration, not a potency): 0%
For compound 4 the middle estimate is 3 percentage points above the measured one; the range from low to high includes it.
By their numbers in this assay, from the lowest: compounds 2, 3, 4 and 1 (each within the scatter of the next).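

Placing thiophen-2-yl on the saturated ring carbon gives no change at the digits printed from compound 3 to compound 4 (within the scatter) in this assay, along with no change at the digits printed from compound 2 to compound 4 (within the scatter) and a number 10 percentage points lower from compound 1 to compound 4 (within the scatter). Until now, every ring on this carbon was a six-membered ring of carbon only, so this result extends the picture to a five-membered aromatic ring with a sulfur atom, and the read-out still stays within the scatter. On these data alone, what remains open is whether a different group on this carbon, such as a carboxylic acid, an amine or a longer alkyl chain, would give a number clear of the scatter. Nothing available offers an explanation for these results.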